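Shortening the Phenethyl Chain on a Uracil Dinucleotide Core

This account rests on a few compounds, and the source may have more. Where it says the series, first, only, none or still open, it means among the compounds named here.

Measured compounds:
compound 1, `O=c1ccn([C@@H]2O[C@H](COP(=O)(O)OP(=O)(O)O)[C@@H](O)[C@H]2O)c(SCCc2ccccc2)n1`, 544 nM
compound 2, `O=c1[nH]c(=S)ccn1[C@@H]1O[C@H](COP(=O)(O)O)[C@@H](O)[C@H]1O`, > 100000 nM
compound 3, `O=c1ccn([C@@H]2O[C@H](COP(=O)(O)O)[C@@H](O)[C@H]2O)c(SCCc2ccccc2)n1`, 1300 nM

The account concerns three measured compounds and one that awaits measurement in an in vitro functional assay on 1321-N1 cells for agonist activity at P2Y purinoceptor 2 (Homo sapiens), read by scintillation proximity assay and inositol phosphate accumulation; a higher number here means that more compound is needed for the effect, a lower number that less compound is needed. Compound 1 gives 544 nM and stands lowest of the two numbers; its nearest neighbour is compound 3, which gives 1300 nM. For compound 2 the assay reports only a limit, > 100000 nM, not a number, as set out in the limit of > 100000 nM in this assay, at which 1 of the 3 values shown sits.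

Within the data shown here, the only step between measured compounds is a 2.4-fold higher number from compound 1 to compound 3 (0.38 log units; beyond the scatter), a change on an oxygen of the shared core. The unmeasured compound 4, `O=c1ccn([C@@H]2O[C@H](COP(=O)(O)OP(=O)(O)O)[C@@H](O)[C@H]2O)c(SCc2ccccc2)n1`, differs from compound 1 elsewhere: phenyl in place of benzyl on a saturated chain carbon bound to a sulfur. Among the measured compounds shown here, nothing among the measured compounds touches this part of the structure, so the step from compound 1 to compound 3 bears on it only as a sign that the core tolerates modest changes with modest movement. For the measured compounds named here, with no direct precedent, a shift no larger than that modest step, in either direction, seems the fair expectation for compound 4.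

On that basis compound 4 is expected to give about 800 nM, within a range of 250 nM to 2500 nM, which corresponds to an estimated step of a 1.5-fold higher number from compound 1 to compound 4 (0.17 log units; within the scatter).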

Compound 4, half-maximal effective concentration: 6200 nM
Compound 4: middle estimate off by 7.8-fold (0.89 log units), on the low side; the measured number lies above the stated range.
By their numbers in this assay, from the lowest: compound 1; then compound 3; then compound 4. At a limit, above all of these: compound 2.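

In this assay, the chain on the sulfur proves to be a sensitive part of the structure: replacing phenethylsulfanyl with benzylsulfanyl, with the rest of the molecule unchanged, gives an 11-fold higher number from compound 1 to compound 4 (1.06 log units; beyond the scatter). This large step stands against the modest one on an oxygen of the shared core, a 2.4-fold higher number from compound 1 to compound 3 (0.38 log units; beyond the scatter), so the small movement seen there does not carry over to this position, and the chain on the sulfur matters more in this assay than that earlier step could show. Nothing measured here gives a reason for the size of this shift.

The compounds shown leave open whether a longer chain, such as phenylpropyl, would lower the number further or raise it again, and whether a cyclohexyl ring in place of the phenyl ring at the end of the chain would keep the value of compound 1. Also open, as far as these compounds go, is whether the same shortening of the chain would have as large an effect on the core of compound 3, since only the core of compound 1 carries both chain lengths.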